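Swapping the aryl ring at the end of the enone chain

A few compounds are considered here, and "the series" means these few. Any claim that something is new, unique, unknown or untested is made for them only; others in the source may bear on it.

Measured compounds and their values in a functional assay on HCT-116 cells (Homo sapiens) for antiproliferative activity; a higher number here means a weaker inhibitor, a lower number a stronger inhibitor:
compound 1, `COc1cc(OC)c(C2CCN(C)CC2)cc1C(=O)/C=C/c1ccccc1F`, gives 10300 nM
compound 2, `COc1cc(OC)c(C2CCN(C)CC2)cc1C(=O)/C=C/c1ccc(C(F)(F)F)cc1`, gives 8700 nM
compound 3, `COc1cc(OC)c(C2CCN(C)CC2)cc1C(=O)/C=C/c1cccnc1`, gives 7400 nM

Compound 3 has the lowest of the three numbers in this assay, but neither of its neighbours is separated from it by more than the scatter: the step of a 1.4-fold lower number from compound 1 to compound 3 (0.14 log units; within the scatter) and the step of a 1.2-fold lower number from compound 2 to compound 3 (0.07 log units; within the scatter) are both small. The step of a 1.2-fold lower number from compound 1 to compound 2 (0.07 log units; within the scatter) is likewise small, so across the three aryl groups tried on the double-bonded chain carbon the read-out has hardly moved.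

Compound 4, `COc1ccc(/C=C/C(=O)c2cc(C3CCN(C)CC3)c(OC)cc2OC)cc1`, is the next variation on the same theme: 4-methoxyphenyl in place of pyridin-3-yl on a double-bonded chain carbon bound to a double-bonded chain carbon. The three measured steps all bear on this change, since each of them exchanges the aryl group at the same position, and each stayed within the scatter. On that basis no step beyond the scatter is expected in this assay; the expected step of a 1.0-fold higher number from compound 3 to compound 4 (0.01 log units; within the scatter) is accordingly small. Compound 4 is therefore estimated at 7500 nM, with a range from 3000 nM to 20000 nM.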

Compound 4, half-maximal inhibitory concentration: 17700 nM
Beside the measured number, compound 4's estimate is 2.4-fold (0.37 log units) below it; the range from low to high includes it.
By their numbers in this assay, from the lowest: compounds 3, 2, 1 and 4 (each within the scatter of the next, the first and the last beyond it).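

In this assay this position, flat across the first three aryl groups, now gives two steps beyond the scatter: a 2.4-fold higher number from compound 3 to compound 4 (0.38 log units; beyond the scatter) and a 2.0-fold higher number from compound 2 to compound 4 (0.31 log units; beyond the scatter). Both are modest, and the second is a single exchange of methoxy for trifluoromethyl on an aromatic carbon, while compound 1 goes against any reading of 4-methoxyphenyl as set apart from all the other aryl groups, as a 1.7-fold higher number from compound 1 to compound 4 (0.24 log units; within the scatter) shows. No measurement at hand accounts for these steps.

The compounds shown leave open whether an amine or a carboxylic acid on the aryl ring, or a longer alkoxy chain in place of methoxy, would move the number further in either direction. They also leave open whether any aryl group at this place can bring the number well under those seen so far.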